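Swapping the Fluorinated Aryl Tail in an Orexin-2 Antagonist

This account rests on a few compounds, and the source may have more. Where it says the series, first, only, none or still open, it means among the compounds named here.

Compounds measured so far, all in a functional assay on CHO cells for antagonist activity at Orexin receptor type 2 (Homo sapiens), read by FLIPR and calcium flux; a higher number here means a weaker inhibitor, a lower number a stronger inhibitor:
- compound 1, `CCc1nc(Cl)c2n1CCN([C@@H](C(=O)NC)c1ccccc1)[C@H]2CCc1ccc(C(F)(F)F)c(F)c1F`, gives 14 nM
- compound 2, `CCc1nc(Cl)c2n1CCN([C@@H](C(=O)NC)c1ccccc1)[C@H]2CCc1cccc(C(F)(F)F)c1F`, gives 9 nM
- compound 3, `CNC(=O)[C@@H](c1ccccc1)N1CCn2c(C3CC3)nc(Cl)c2[C@@H]1CCc1ccc(C(F)(F)F)cc1`, gives 9 nM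

Compound 3 sits at the low end of these three numbers, level with compound 2 at the digits shown, while compound 1 differs from it only by an amount within the scatter. The three compounds are therefore indistinguishable on potency in this assay.

Compound 4, `CNC(=O)[C@@H](c1ccccc1)N1CCn2c(C3CC3)nc(Cl)c2[C@@H]1CCc1ccc(OC(F)F)c(F)c1`, is compound 3 with one change: 4-(difluoromethoxy)-3-fluorophenyl in place of 4-(trifluoromethyl)phenyl on a saturated chain carbon, two bonds along the chain from a saturated ring carbon. Among the compounds with values here, the only measured step that touches the same place is the one between compound 1 and compound 2, where a different fluorinated aryl group replaced another: a 1.6-fold lower number from compound 1 to compound 2 (0.19 log units; within the scatter). That step, which also exchanged one fluorine-bearing aryl group for another on the same chain carbon, did not move the number beyond the scatter. Within the data shown here, the change to compound 4 is of the same kind, although it brings in an oxygen and a hydrogen-bond acceptor that none of the measured compounds carry, so there is no direct precedent for that part.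

On that basis compound 4 is expected to stay close to compound 3, with an estimated step of a 1.3-fold higher number from compound 3 to compound 4 (0.12 log units; within the scatter) in this assay. The estimate for compound 4 is 12 nM, with a range from 4 nM to 40 nM.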

Compound 4, half-maximal inhibitory concentration: 2 nM
For compound 4 the middle estimate is 6.0-fold (0.78 log units) above the measured one; the whole stated range lies above it.
By their numbers in this assay, from the lowest: compound 4; then compounds 2, 3 and 1 (each within the scatter of the next).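

In this assay the aryl group on this chain is not a neutral place for change: swapping 4-(trifluoromethyl)phenyl for 4-(difluoromethoxy)-3-fluorophenyl gives a 4.5-fold lower number from compound 3 to compound 4 (0.65 log units; beyond the scatter) and so moves the compound towards stronger inhibition. The earlier exchange of one fluorinated aryl group for another gave only a 1.6-fold lower number from compound 1 to compound 2 (0.19 log units; within the scatter) and left open whether this position could respond at all, so the new step shows that the particular fluorinated aryl group can matter here. Nothing measured here explains what gives this change its effect.

The entering group brings an oxygen, a hydrogen-bond acceptor and a different pattern of fluorines all at once, so the compounds shown cannot separate the part played by the difluoromethoxy group from that of the added fluorine, nor say whether the same swap would carry over to the core of compound 1. Also open, going by these compounds, is how a plain methoxy or a trifluoromethoxy group would read at this place on the chain.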